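Swapping Fluoro for Trifluoromethoxy on the Sulfonyl Ring

This account rests on a few compounds, and the source may have more. Where it says the series, first, only, none or still open, it means among the compounds named here.

Measured so far in a functional assay on NCI-H1975 cells (Homo sapiens) for inhibition, read by sulforhodamine B assay, tested at 10 uM; on this read-out lower numbers stand for less inhibition and higher numbers for more inhibition at the one concentration tested (going by the name of the read-out):
compound 1 `CN1CCN(c2ccc(C3=NN(S(=O)(=O)c4ccc(OC(F)(F)F)cc4)C(c4ccc(N(C)C)cc4)C3)cc2)CC1` gives 26.5%
compound 2 `Cc1ccc(S(=O)(=O)N2N=C(c3ccc(-n4cncn4)cc3)CC2c2ccc(N(C)C)cc2)cc1` gives 20%
compound 3 `CN(C)c1ccc(C2CC(c3ccc(-n4cncn4)cc3)=NN2S(=O)(=O)c2ccc(F)cc2)cc1` gives -0.5%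

Compound 3 stands lowest of the three numbers. Its nearest neighbour is compound 2, whose number is higher by a margin beyond the scatter, and compound 1 lies further above still. For the measured compounds named here, the one step that can be read directly is a number 20.5 percentage points lower from compound 2 to compound 3 (beyond the scatter), which shows that replacing methyl by fluoro on the sulfonyl-bearing ring took the inhibition down to essentially nothing.

Compound 4 `CN(C)c1ccc(C2CC(c3ccc(-n4cncn4)cc3)=NN2S(=O)(=O)c2ccc(OC(F)(F)F)cc2)cc1` has not yet been measured. It differs from compound 3 in one place: trifluoromethoxy in place of fluoro on an aromatic carbon. Going by the values given here, compound 1 also carries a trifluoromethoxy group at this position, but it differs from compound 3 elsewhere too; the value of compound 1 26.5% shows only that a trifluoromethoxy-bearing compound can reach a moderate number. The step from methyl to fluoro was modest and downward; going from fluoro to a larger group is expected to move the number back upward, probably toward the range of compound 2 and compound 1. This means an expected step of a number 15.5 percentage points higher from compound 3 to compound 4 (beyond the scatter). For compound 4 the estimate is 15%, with a likely range from -5% to 35%.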

Compound 4, a percentage reported as inhibition, at one concentration (the size of the read-out at that concentration, not a potency): 11.1%
For compound 4 the middle estimate is 3.9 percentage points above the measured one; the range from low to high includes it.
By their numbers in this assay, from the lowest: compound 3; then compounds 4, 2 and 1 (each within the scatter of the next, the first and the last beyond it).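

In this assay the fluoro group now stands apart from two other groups on this aromatic carbon, not from methyl alone, with a number 11.6 percentage points higher from compound 3 to compound 4 (beyond the scatter) when trifluoromethoxy enters. Trifluoromethoxy and methyl, however, cannot be told apart here, even though the first brings more heavy atoms: exchanging them gives a number 8.9 percentage points lower from compound 2 to compound 4 (within the scatter). For the compounds shown here, with trifluoromethoxy held fixed, a single change at a second place on the molecule can also be read for the first time, and replacing 4-methylpiperazin-1-yl by 1H-1,2,4-triazol-1-yl gives a number 15.4 percentage points lower from compound 1 to compound 4 (beyond the scatter).

No supporting measurement is available to explain why fluoro differs from the other two groups at this position, or why the second place affects the number. Still open, on these data alone, is how a chloro, a methoxy or an amine on the same aromatic carbon would compare, and whether the trifluoromethoxy and methyl compounds would remain indistinguishable at concentrations other than the single one tested.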